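Replacing a chloro with a dimethyl-oxazole on the benzyl ring

The compounds below may be only part of what the source reports. "The series", "measured", "known", "first", "only" and "open" are said of these compounds alone.

Compound 1 `CC(C)(N)C(=O)N[C@H](COCc1ccccc1Cl)c1nnnn1CCOC(=O)NCCCCO` is the reference. In a functional assay on cells for inhibition of growth hormone secretagogue receptor type 1 (Homo sapiens), read by FLIPR and calcium flux (on this read-out higher numbers stand for an effect only at larger amounts of compound and lower numbers for an effect already at smaller amounts), compound 1 gives 0.45 nM, the lowest number among the three measured compounds. Compound 2 `CC(C)(N)C(=O)N[C@H](COCc1cccc(Cl)c1Cl)c1nnnn1CCOC(=O)NCCCCO` gives 0.61 nM, and a 1.4-fold higher number from compound 1 to compound 2 (0.13 log units; within the scatter). Compound 3 `CC(C)(N)C(=O)N[C@H](COCc1ccc(OC(F)(F)F)cc1)c1nnnn1CCOC(=O)NCCCCO` gives 33.2 nM, and a 74-fold higher number from compound 1 to compound 3 (1.87 log units; beyond the scatter). Compound 4 `Cc1noc(C)c1-c1ccccc1COC[C@@H](NC(=O)C(C)(C)N)c1nnnn1CCOC(=O)NCCCCO` differs from compound 1 by 3,5-dimethyl-1,2-oxazol-4-yl in place of chloro on an aromatic carbon. The step from compound 1 to compound 2 shows that an extra chloro on this ring stays within the scatter, while the step from compound 1 to compound 3 shows that another substitution pattern on the same ring can cost a great deal. Neither step places a larger group where the chloro sits, so a moderate rise is expected, a 6.7-fold higher number from compound 1 to compound 4 (0.82 log units; beyond the scatter). Compound 4 is estimated at 3 nM, with a range from 0.5 nM to 20 nM.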

Compound 4, half-maximal effective concentration: 1.04 nM
The estimate for compound 4 lay 2.9-fold (0.46 log units) above the measured number, within the range that was stated.
By their numbers in this assay, from the lowest: compounds 1, 2 and 4 (each within the scatter of the next, the first and the last beyond it); then compound 3.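

The aromatic carbon that holds the chloro in compound 1 accepts a much larger group at only a small cost: 3,5-dimethyl-1,2-oxazol-4-yl brings 7 heavy atoms in place of 1, with two hydrogen-bond acceptors and a second ring, and the step is a 2.3-fold higher number from compound 1 to compound 4 (0.36 log units; beyond the scatter). Size alone therefore does not produce a large loss here. No measurement available explains why the change is so small. On these data alone, whether a plain phenyl ring, an aminomethyl group or a carboxylic acid on this same carbon would behave alike remains open. So does whether the two ring methyl groups matter.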